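Replacing Cyclobutyl with Phenyl on the Amide Carbonyl

The compounds below may be only part of what the source reports. "The series", "measured", "known", "first", "only" and "open" are said of these compounds alone.

Compound 1 `COc1ccc(N)c(C(=O)CCNC(C)=O)c1` gives 30.7% in an assay for inhibition of Nitric oxide synthase, inducible (Homo sapiens), read by scintillation counting, with a stated time of 30 min, tested at 1 mM; a higher number here means more inhibition at the concentration tested (going by the name of the read-out), a lower number less inhibition. Compound 2 `CCCCC(=O)NCCC(=O)c1cc(OC)ccc1N` gives 14.1% in this assay, and compound 3 `COc1ccc(N)c(C(=O)CCNC(=O)C2CCC2)c1` gives 0.01%, the lowest of the three measured numbers. Its nearest neighbour is shown by a number 14.1 percentage points lower from compound 2 to compound 3 (beyond the scatter), its furthest by a number 30.7 percentage points lower from compound 1 to compound 3 (beyond the scatter).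

Compound 4 `COc1ccc(N)c(C(=O)CCNC(=O)c2ccccc2)c1` differs from compound 3 by phenyl in place of cyclobutyl on a carbonyl carbon. The two steps that bear on this change sit on the same carbonyl carbon: a number 30.7 percentage points lower from compound 1 to compound 3 (beyond the scatter) and a number 14.1 percentage points lower from compound 2 to compound 3 (beyond the scatter), both lowering inhibition as the group on that carbon grew. Phenyl is a further large group there, so compound 4 is expected to stay low, with a number 5 percentage points higher from compound 3 to compound 4 (within the scatter). Compound 4 is therefore estimated at 5%, expected between 0% and 20%.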

Compound 4, a percentage reported as inhibition, at one concentration (the size of the read-out at that concentration, not a potency): 10.9%
Estimate against measurement, compound 4: 5.9 percentage points below; the measured number falls inside the stated range.
By their numbers in this assay, from the lowest: compound 3; then compounds 4 and 2 (each within the scatter of the next); then compound 1.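

In this assay the ring on this carbonyl carbon matters: the change to phenyl gives a number 10.9 percentage points higher from compound 3 to compound 4 (beyond the scatter) and so recovers part of what cyclobutyl lost. Phenyl and butyl cannot be told apart, as a number 3.2 percentage points lower from compound 2 to compound 4 (within the scatter) shows, while a number 19.8 percentage points lower from compound 1 to compound 4 (beyond the scatter) keeps the methyl compound clearly ahead of phenyl. Nothing measured here explains these differences.

From the compounds shown here alone, it remains open whether a pyridine ring, a benzyl group or a phenyl ring carrying a methoxy group on this carbonyl carbon would stay near compound 4 or approach compound 1.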